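A few compounds are considered here, and "the series" means these few. Any claim that something is new, unique, unknown or untested is made for them only; others in the source may bear on it.

Compound 1 `O=c1[nH]c(=O)n(COC(CO)CO)cc1O` is a pyrimidinedione bearing an open-chain diol substituent on a ring nitrogen. In a functional assay on SW-620 cells (Homo sapiens) for inhibition, read by MTT assay, with a stated time of 72 h (on this read-out higher numbers stand for weaker inhibition and lower numbers for stronger inhibition), compound 1 gives > 100000 nM, which is a limit of the assay and not a measured number. A second compound from the same set, compound 2 `NCC(=O)Nc1c[nH]c(=O)[nH]c1=O`, carries an aminoacetamide group on the core instead of the diol chain. In this assay compound 2 also gives > 100000 nM, again a limit rather than a number. Compound 1 therefore stands on no number at all: both of the values shown sit at the same limit, as the limit of > 100000 nM in this assay, at which 2 of the 2 values shown sit, records, and no ranking between compound 1 and compound 2 can be drawn from them.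

Compound 3 `O=c1ccn(COC(CO)CO)c(=O)[nH]1` differs from compound 1 in one place (hydrogen in place of hydroxy on an aromatic carbon). Hydrogen in place of hydroxy on an aromatic carbon is the whole of the change. With compound 1 already at the limit, the step from compound 1 to compound 3 is expected to be a step that the limit leaves unreadable from compound 1 to compound 3, that is, no movement beyond the scatter that could be seen. Compound 3 is expected to give 200000 nM, with a range from 50000 nM to 1000000 nM.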

Compound 3, half-maximal inhibitory concentration: > 100000 nM
Compound 3: no number, only a limit (the forecaster's own chance of this, stated with the estimate: 85%); the middle value lies beyond the limit too.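

In this assay compound 3 gives > 100000 nM, which is a limit of the assay and not a number. No step can be read between compound 1 and compound 3, and the result gives no comparison: the limit of > 100000 nM in this assay, at which 3 of the 3 values shown sit.

The compounds shown leave open whether hydrogen in place of hydroxy on that aromatic carbon changes inhibition, and how compounds 1, 2 and 3 would rank on measured numbers.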